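Cytotoxicity of a 4-Bromobenzyl Ether: An Expected Outcome

The source may hold more compounds than are shown below. What is called first, only, known or untested is meant among the compounds shown, and "the series" means these compounds.

Measured compounds:
- compound 1 `CCC1(Cc2ccccc2)OS(=O)(=O)C=C1OC`: > 400000 nM
- compound 2 `CCC1(Cc2ccccc2)OS(=O)(=O)C=C1OC(c1ccccc1)c1ccccc1`: >= 80000 nM
- compound 3 `CC1(Cc2ccccc2)OS(=O)(=O)C=C1OCc1ccccc1`: > 400000 nM

All three measured compounds share one core and were tested in an ADME assay on HEL cells (Homo sapiens) for cytotoxicity, with a stated time of 3 days; on this read-out lower numbers stand for higher toxicity in this test and higher numbers for lower toxicity in this test. For compound 1 the value is a limit of the assay and not a number; it rests at the limit of > 400000 nM in this assay, at which 2 of the 3 values shown sit. Compound 3 rests at the same limit. Compound 2 rests at a different limit, (the limit of >= 80000 nM in this assay, at which 1 of the 3 values shown sits). Among the compounds with values here, none of the three gives a measured number, so no step between them can be sized, and the readings only show that none reached a cytotoxic concentration within the tested range.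

Compound 4 `CCC1(Cc2ccccc2)OS(=O)(=O)C=C1OCc1ccc(Br)cc1` has not yet been measured in this assay. It differs from compound 1 by 4-bromophenyl in place of hydrogen on a saturated chain carbon bound to an oxygen on an unsaturated carbon. Within the data shown here, since no measured step is known, no change beyond the scatter is expected in this assay from this change. Compound 4 is therefore expected to give 400000 nM, within a range from 100000 nM to 800000 nM. This estimate means an expected step of a number no higher from compound 1 to compound 4 (the limit leaves the size open), most likely again reported only as a limit.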

Compound 4, minimum cytotoxic concentration: 80000 nM
The estimate for compound 4 lay 5.0-fold (0.70 log units) above the measured number; the whole stated range lies above it.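

In this assay compound 4 is the only compound shown that gives an actual number and not a limit, so with 4-bromophenyl in this place a cytotoxic concentration was reached within the tested range. Swapping hydrogen for 4-bromophenyl on the saturated chain carbon bound to an oxygen on an unsaturated carbon gives an at least 5.0-fold lower number from compound 1 to compound 4 (0.69 log units; beyond the scatter) and so shows that the read-out can respond to a change at this position. That size is only a minimum, because the reading for compound 1 is a limit of the assay: the limit of > 400000 nM in this assay, at which 2 of the 4 values shown sit.

Whether the bromine or the rest of the 4-bromobenzyl group accounts for this step remains open. A 4-chlorobenzyl group or a longer chain in the same place on the core of compound 1 would help to separate the two.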